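From a Urea to an Amide on a Shared Core

A few compounds are considered here, and "the series" means these few. Any claim that something is new, unique, unknown or untested is made for them only; others in the source may bear on it.

In a functional assay on NCI/ADR-RES cells (Homo sapiens) for inhibition, read by sulforhodamine B assay, with a stated time of 48 h (a higher number here means a weaker inhibitor of growth, a lower number a stronger inhibitor of growth), compound 2 `COc1cc(-c2nn(-c3cccc(NC(=O)Nc4cccc(C(F)(F)F)c4)c3)cc2-c2ccncc2)ccc1Cl` gives 783 nM, and compound 1 `COc1cc(-c2nn(-c3cccc(NC(=O)Nc4ccc(Cl)c(Cl)c4)c3)cc2-c2ccncc2)ccc1Cl` gives 990 nM; the two values stand within the scatter of one another, so neither can be called the stronger inhibitor. Going by the values given here, the only measured step, a 1.3-fold lower number from compound 1 to compound 2 (0.10 log units; within the scatter), exchanges one aromatic substituent pattern for another while keeping the urea intact. Compound 3 `COc1cc(-c2nn(-c3cccc(NC(=O)c4ccc(Cl)c(C(F)(F)F)c4)c3)cc2-c2ccncc2)ccc1Cl` has not yet been measured in this assay. It differs from compound 2 by 4-chloro-3-(trifluoromethyl)phenyl in place of (3-(trifluoromethyl)phenyl)amino on a carbonyl carbon: the urea of compound 2 becomes an amide whose carbonyl carbon carries the 4-chloro-3-(trifluoromethyl)phenyl and whose other neighbour is the amide-type nitrogen. Among the compounds with values here, no recorded step touches this loss of the amino group, so the measured data give no direction for it. In this assay the expected step is a 1.3-fold higher number from compound 2 to compound 3 (0.11 log units; within the scatter), none beyond the scatter, but with wide uncertainty. The estimate for compound 3 is 1000 nM, with a range from 300 nM to 3500 nM.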

Compound 3, concentration for 50% growth inhibition: 1290 nM
Compound 3: middle estimate off by 1.3-fold (0.11 log units), on the low side; the measured number falls inside the stated range.
By their numbers in this assay, from the lowest: compounds 2, 1 and 3 (each within the scatter of the next).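

Replacing the aryl-amino group on the carbonyl carbon gives a 1.6-fold higher number from compound 2 to compound 3 (0.22 log units; within the scatter) and a 1.3-fold higher number from compound 1 to compound 3 (0.11 log units; within the scatter) in this assay on the shared core. The earlier step varied only the aromatic substituents within the urea, whereas these two show that 4-chloro-3-(trifluoromethyl)phenyl can stand in place of either aryl-amino group with no step beyond the scatter, even though the hydrogen-bond donor counted in each leaving group is gone. No measurement is at hand that would explain this reading.

The compounds shown do not tell whether a sulfonamide or a thiourea would read the same at this link. They also leave open how an amide carrying a 3-(trifluoromethyl)phenyl or a 3,4-dichlorophenyl group would compare, since the aryl substituents and the link differ together here.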